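The source may hold more compounds than are shown below. What is called first, only, known or untested is meant among the compounds shown, and "the series" means these compounds.

Cytotoxicity across the series is read in an ADME assay on MT4 cells (Homo sapiens) for cytotoxicity; on this read-out higher numbers stand for lower toxicity in this test and lower numbers for higher toxicity in this test. Compound 1 `O=C(NCc1ccc(F)cc1)c1nc[nH]c1C(=O)O` gives only a limit there, > 20000 nM. Compound 2 `O=C(Nc1ccccn1)c1nc[nH]c1C(=O)O` likewise gives only a limit, > 20000 nM. Within the data shown here, compound 2 therefore stands at the limit, where every value so far sits (the limit of > 20000 nM in this assay, at which 2 of the 2 values shown sit). Compound 3 `O=C(Nc1ccccn1)c1nc[nH]c1C(=O)N1CCC(O)CC1` alters compound 2 at the carbonyl carbon: 4-hydroxypiperidin-1-yl in place of hydroxy on a carbonyl carbon. No measured step is available, and with both shown values at the limit no change beyond the scatter is expected in this assay, a step that the limit leaves unreadable from compound 2 to compound 3. Compound 3 is estimated at 30000 nM, between 10000 nM and 100000 nM, most likely reported once more as a limit.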

Compound 3, half-maximal cytotoxic concentration: > 20000 nM
Compound 3 was reported as a limit (the forecaster's own chance of this, stated with the estimate: 75%); the middle value lies beyond the limit too.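

Compound 2 and compound 3 both stand only as limits in this assay; no step can be read between them. The compounds shown leave open where the half-maximal cytotoxic concentration of any of them lies, and whether 4-hydroxypiperidin-1-yl in place of hydroxy changes it.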